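A few compounds are considered here, and "the series" means these few. Any claim that something is new, unique, unknown or untested is made for them only; others in the source may bear on it.

Compound 1 `CCC(CC)O[C@@H]1C=C(C(=O)O)C[C@H](NC(C)=N)[C@H]1NC(C)=O`: 1.13 h
Compound 2 `CCOC(=O)C1=C[C@@H](OC(CC)CC)[C@H](NC(C)=O)[C@@H](N/C(N)=N\O)C1`: 1.15 h

In an ADME assay on the whole organism (strain Sprague-Dawley) for metabolic stability, with Rattus norvegicus as the target, read by LC-MS, at a dose of 50 mg/kg by the oral route (on this read-out higher numbers stand for a longer-lived compound and lower numbers for a shorter-lived compound), compound 2 gives 1.15 h, which lies within the scatter of compound 1 at 1.13 h. Neither compound stands apart on these numbers, and two values give no basis for a trend across the series.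

Compound 3 `CCOC(=O)C1=C[C@@H](OC(CC)CC)[C@H](NC(C)=O)[C@@H](NC(C)=N)C1` has not yet been measured. It keeps the shared core of compound 2 and differs from it on an amine nitrogen (a group of 3 heavy atoms (2 carbon, 1 nitrogen; no ring) in place of a group of 4 heavy atoms (1 carbon, 2 nitrogen, 1 oxygen; no ring), on an amine nitrogen). Going by the values given here, no step between measured compounds that differ in one place is available, so nothing shows directly how this assay responds to this change. Among the compounds with values here, the only guide is the narrow spread of the two values, with compound 2 at 1.15 h and compound 1 at 1.13 h. On that limited evidence, no change beyond the scatter is expected, and neither direction is favoured. The expected move is a 1.0-fold higher number from compound 2 to compound 3 (0.02 log units; within the scatter), which is an estimate and stays within the scatter. For compound 3 the estimated half-life is 1.2 h, with an expected range from 0.7 h to 2 h.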

Compound 3, half-life: 0.7 h
The estimate for compound 3 lay 1.7-fold (0.23 log units) above the measured number; measured number inside the range.
By their numbers in this assay, from the lowest: compounds 3, 1 and 2 (each within the scatter of the next).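

Read in this assay, the amine nitrogen whose other neighbours are a saturated ring carbon now has a one-place comparison: the group of 3 heavy atoms in place of the group of 4 heavy atoms gives a 1.6-fold lower number from compound 2 to compound 3 (0.22 log units; within the scatter) and so stays within the scatter. Ethyl in place of hydrogen on an oxygen next to a carbonyl group gives a 1.6-fold lower number from compound 1 to compound 3 (0.21 log units; within the scatter) and also stays within the scatter, so neither exchange is resolved on this read-out. No measurement among the data shown accounts for either step.

Still open is whether a plain amine or a guanidine on the same amine nitrogen would give a half-life beyond the scatter of these compounds. Equally open is whether a longer chain, such as butyl, in place of ethyl on that oxygen would do so, since the two steps shown cover only one exchange at each place.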